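A few compounds are considered here, and "the series" means these few. Any claim that something is new, unique, unknown or untested is made for them only; others in the source may bear on it.

Compound 1 `O=C1N=C(NN2Cc3ccccc3N=C2c2ccccc2)S/C1=C/c1ccccc1` sets the low end of this set: in a functional assay on A549 cells (Homo sapiens) for cytotoxicity, read by MTT assay, with a stated time of 4 h (on this read-out lower numbers stand for stronger inhibition and higher numbers for weaker inhibition), compound 1 gives 720 nM. Compound 2 `O=C1N=C(NN2Cc3ccccc3N=C2c2ccccc2)S/C1=C/c1ccc(Br)cc1` carries bromo in place of hydrogen on an aromatic carbon, and in this assay compound 2 gives 21300 nM, so that a 30-fold higher number from compound 1 to compound 2 (1.47 log units; beyond the scatter). Compound 3 `O=C(CNc1ccc(Cl)cc1Cl)Nn1c(-c2ccccc2)nc2ccccc2c1=O` belongs to a different core, and in this assay compound 3 gives 187000 nM, the highest of the three numbers, beyond the scatter from both compound 2 and compound 1.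

Compound 4 `O=C(CNc1ccccc1)Nn1c(-c2ccccc2)nc2ccccc2c1=O` differs from compound 3 in one place: phenyl in place of 2,4-dichlorophenyl on an amine nitrogen. Among the compounds with values here, the only measured step touching a halogen on an aromatic ring is the one from compound 1 to compound 2, where bromo entering raised the number greatly; here two chlorines leave instead, on another core, so it bears only loosely. A modest step toward a lower number is therefore expected for compound 4, with wide uncertainty, as a 2.7-fold lower number from compound 3 to compound 4 (0.43 log units; beyond the scatter). Compound 4 is estimated at 70000 nM, within 10000 nM to 400000 nM.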

Compound 4, half-maximal inhibitory concentration: 13300 nM
The estimate for compound 4 lay 5.3-fold (0.72 log units) above the measured number, within the range that was stated.
By their numbers in this assay, from the lowest: compound 1; then compounds 4 and 2 (each within the scatter of the next); then compound 3.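

In this assay, the amine nitrogen of compound 3 proves sensitive to what it carries: phenyl in place of 2,4-dichlorophenyl gives a 14-fold lower number from compound 3 to compound 4 (1.15 log units; beyond the scatter), a large step. Read with a 30-fold higher number from compound 1 to compound 2 (1.47 log units; beyond the scatter), this makes two pairs, on different cores, in which the member with halogen on an aromatic ring has the higher number, and neither shown pair goes against this. Both chlorines leave in a single step, however, so the change cannot be assigned to either one. No measurement shown here accounts for the size of this step.

As far as these compounds go, it remains open whether a single chloro group would give a number nearer compound 3 or compound 4. Also open, from the compounds shown here alone, is how a methoxy group or a carboxylic acid on that phenyl ring would read.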